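From Allyloxy to Chloro in a Cytotoxicity Series

The compounds below may be only part of what the source reports. "The series", "measured", "known", "first", "only" and "open" are said of these compounds alone.

Compound 1 `C=CCOc1cc(C2=C(c3cc(OC)c(OC)c(OC)c3)C(=O)C(O)C2)ccc1OC`: > 100 ug/mL, a limit
Compound 2 `COc1ccc(OC)c(C2=C(c3cc(OC)c(OC)c(OC)c3)C(=O)CC2O[SiH2]C(C)(C)C)c1`: 100 ug/mL
Compound 3 `COC(=O)c1cc(C2=C(c3cc(OC)c(OC)c(OC)c3)C(=O)CC2O[SiH2]C(C)(C)C)ccc1OC`: > 100 ug/mL, a limit

All three compounds were tested in an ADME assay on DU-145 cells (Homo sapiens) for cytotoxicity, read by MTT assay, with a stated time of 72 h; on this read-out lower numbers stand for stronger inhibition and higher numbers for weaker inhibition. Compound 1 has no number of its own, only a limit. Among the compounds with values here, it stands at the limit of > 100 ug/mL in this assay, at which 2 of the 3 values shown sit, and compound 2 gives the only number in the set.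

The next compound, compound 4 `COc1ccc(C2=C(c3cc(OC)c(OC)c(OC)c3)C(=O)C(O)C2)cc1Cl`, has not yet been measured. It differs from compound 1 by one change on the aromatic ring, chloro in place of allyloxy on an aromatic carbon.

Within the data shown here, only one measured step is available, a number no lower from compound 2 to compound 3 (the limit leaves the size open). It also replaces groups on an aromatic ring, but its size cannot be read, and it does not involve chloro or allyloxy. It therefore gives only weak guidance. Among the measured compounds shown here, nothing measured so far shows a compound clearly stronger than the values at the top of this range, yet the limit on compound 1 leaves room for a move towards lower numbers. A modest move in that direction is expected, and this assay may again report only a limit. The expected change is an at least 1.6-fold lower number from compound 1 to compound 4 (0.22 log units; that floor lies within the scatter). For compound 4 the estimated value is 60 ug/mL, with an expected range from 10 ug/mL to 150 ug/mL.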

Compound 4, half-maximal inhibitory concentration: 40 ug/mL
Estimate against measurement, compound 4: 1.5-fold (0.18 log units) above; the range from low to high includes it.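

In this assay, chloro in place of allyloxy, on an aromatic carbon ortho to a methoxy group and meta to a large group, gives an at least 2.5-fold lower number from compound 1 to compound 4 (0.39 log units; beyond the scatter). Within the data shown here, this is the first step whose size can be read, and it shows that this position on the ring can respond to a single change: an allyloxy of 4 heavy atoms gives way to a chloro of 1 heavy atom, and the read-out moves to lower numbers. The step gives only a floor, and its true size stays unknown, as compound 1 has a limit and no number of its own: the limit of > 100 ug/mL in this assay, at which 2 of the 4 values shown sit.

The compounds shown leave open whether the lower number comes from the chloro itself or from the loss of the allyloxy, and how an amine, a carboxylic acid or a longer chain at this carbon would read. They also leave open whether the same change would give a step of similar size on the core of compound 2 or of compound 3.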